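Replacing 3-chloropyridin-2-yl with 2-methoxyphenyl on an amide-type nitrogen

The source may hold more compounds than are shown below. What is called first, only, known or untested is meant among the compounds shown, and "the series" means these compounds.

Of the compounds shown here, three sharing one core have been tested in a functional assay on Shh Light II cells (Mus musculus) for inhibition, read by a luciferase reporter; a lower number here means a stronger inhibitor, a higher number a weaker inhibitor. Compound 1 (`O=C(NCC1CCC1)N1CCC(c2nc(-c3ccc4ccccc4n3)no2)CC1`), with cyclobutylmethyl on an amide-type nitrogen, gives 410 nM. Compound 2 (`N#Cc1ccccc1NC(=O)N1CCC(c2nc(-c3ccc4ccccc4n3)no2)CC1`), with 2-cyanophenyl at that place, gives 190 nM. Compound 3 (`O=C(Nc1ncccc1Cl)N1CCC(c2nc(-c3ccc4ccccc4n3)no2)CC1`), with 3-chloropyridin-2-yl, gives 2800 nM, the highest number of the three, and its steps to both others lie beyond the scatter.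

Compound 4 (`COc1ccccc1NC(=O)N1CCC(c2nc(-c3ccc4ccccc4n3)no2)CC1`) differs from compound 3 in one place: 2-methoxyphenyl in place of 3-chloropyridin-2-yl on an amide-type nitrogen. In words, 2-methoxyphenyl stands in place of 3-chloropyridin-2-yl on an amide-type nitrogen.

For the measured compounds named here, three measured steps concern this same place. The largest is a 15-fold higher number from compound 2 to compound 3 (1.17 log units; beyond the scatter), while the others are a 6.8-fold higher number from compound 1 to compound 3 (0.83 log units; beyond the scatter) and a 2.2-fold lower number from compound 1 to compound 2 (0.33 log units; beyond the scatter). Going by the values given here, compound 2, at 190 nM, is the only tested compound with a six-membered aromatic ring of carbon only here, and compound 4 has such a ring too. Among the compounds with values here, no tested compound carries 2-methoxyphenyl, so only part of the large step is expected to be recovered. The expected change is a 6.7-fold lower number from compound 3 to compound 4 (0.82 log units; beyond the scatter), a sizeable move towards stronger inhibition in this assay. Compound 4 is estimated at 420 nM, with an expected range of 130 nM to 1400 nM.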

Compound 4, half-maximal inhibitory concentration: 410 nM
Compound 4: middle estimate off by 1.0-fold (0.01 log units), on the high side; measured number inside the range.
By their numbers in this assay, from the lowest: compound 2; then compounds 1 and 4 (each within the scatter of the next); then compound 3.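

In this assay, 2-methoxyphenyl on the amide-type nitrogen gives a 6.8-fold lower number from compound 3 to compound 4 (0.83 log units; beyond the scatter) and so joins 2-cyanophenyl as a second group with a six-membered aromatic ring of carbon only that stands clear of 3-chloropyridin-2-yl. That ring does not fix the number by itself, as methoxy in place of cyano on an aromatic carbon gives a 2.2-fold higher number from compound 2 to compound 4 (0.33 log units; beyond the scatter) in this series, so the group carried on the ring also counts at this place. An aromatic ring also holds no general edge over a saturated group here, since 2-methoxyphenyl in place of cyclobutylmethyl gives no change at the digits printed from compound 1 to compound 4 (within the scatter) and only compound 2 among the carbon-only aromatic examples goes beyond compound 1.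

The compounds shown do not separate the ring nitrogen from the chlorine in 3-chloropyridin-2-yl, and they leave open how plain phenyl, 2-chlorophenyl, or a ring bearing an amine or a carboxylic acid would read at this place. No available evidence accounts for the differences among these groups.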